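A few compounds are considered here, and "the series" means these few. Any claim that something is new, unique, unknown or untested is made for them only; others in the source may bear on it.

Compounds measured in a functional assay on MV4-11 cells (Homo sapiens) for antiproliferative activity, read by CCK-8 assay, with a stated time of 72 h (on this read-out higher numbers stand for weaker inhibition and lower numbers for stronger inhibition), are as follows:
- compound 1 `Cc1cc(F)cc(C)c1Oc1ccc(C(C)(C)O)cc1-c1cn(C)c(=O)c2[nH]c(C(=O)NCc3ccc(C(=O)NO)cc3)cc12` (440 nM)
- compound 2 `Cn1cc(-c2ccccc2Oc2ccccc2)c2cc(C(=O)NCCCCCC(=O)NO)[nH]c2c1=O` (610 nM)
- compound 3 `Cc1cc(F)cc(C)c1Oc1ccc(C(C)(C)O)cc1-c1cn(C)c(=O)c2[nH]c(C(=O)NCCCCCCC(=O)NO)cc12` (300 nM)

In this assay compound 2 at 610 nM lies within the scatter of compound 1 at 440 nM. Its gap to compound 3 at 300 nM lies just beyond the scatter, with compound 2 showing the weaker inhibition.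

The unmeasured compound 4 `Cn1cc(-c2ccccc2Oc2ccccc2)c2cc(C(=O)NCCCCC(=O)NO)[nH]c2c1=O` keeps the core of compound 2 but has hydroxycarbamoyl in place of (hydroxycarbamoyl)methyl on a saturated chain carbon, four bonds along the chain from an amide-type nitrogen. The chain thus goes from 4-(hydroxycarbamoyl)butyl to 3-(hydroxycarbamoyl)propyl in the shorter reading of the same difference.

Within the data shown here, no measured step alters chain length alone. Among the measured compounds shown here, the one measured step, a 1.5-fold lower number from compound 1 to compound 3 (0.17 log units; within the scatter), exchanges a different group on another core, and it suggests only that this end of the molecule can change with little effect on the number. Compound 2 and compound 3 differ in more than one place, so their values offer only a weak hint on direction.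

A small change is therefore expected, within the scatter and leaning towards weaker inhibition. The expected step is a 1.3-fold higher number from compound 2 to compound 4 (0.12 log units; within the scatter), by this estimate. For compound 4 the estimated value is 800 nM, with an expected range from 300 nM to 2000 nM.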

Compound 4, half-maximal inhibitory concentration: 180 nM
The estimate for compound 4 lay 4.4-fold (0.65 log units) above the measured number; measured number below the stated range.
By their numbers in this assay, from the lowest: compounds 4, 3, 1 and 2 (each within the scatter of the next, the first and the last beyond it).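

In this assay, the change from 4-(hydroxycarbamoyl)butyl to 3-(hydroxycarbamoyl)propyl on the core of compound 2 gives a 3.4-fold lower number from compound 2 to compound 4 (0.53 log units; beyond the scatter), with nothing else in the molecule altered. Among these compounds, the only earlier step between compounds differing in one place, a 1.5-fold lower number from compound 1 to compound 3 (0.17 log units; within the scatter), exchanged a different group on another core and stayed within the scatter, whereas this pair shows that chain length alone can move the number beyond the scatter, and that the shorter chain gives the stronger inhibition on this core. Nothing available accounts for this difference.

The compounds shown leave open whether the number would keep falling with a still shorter 2-(hydroxycarbamoyl)ethyl chain or rise again with a longer chain on this core, since a single pair of lengths fixes a direction for that pair only and not a trend. They also leave open whether the same shortening would act alike on the core of compound 3, and how a carboxylic acid in place of the hydroxycarbamoyl end would read in this assay.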